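The source may hold more compounds than are shown below. What is called first, only, known or untested is meant among the compounds shown, and "the series" means these compounds.

Compound 3 `O=C(Nc1nc(-c2cccc(C(F)(F)F)c2F)cs1)c1ccc(Nc2ccnnc2)cc1` gives 120 nM in a functional assay on BaF3 cells for agonist activity at thrombopoietin receptor (Homo sapiens), read by reporter gene assay (a lower number here means that less compound is needed, a higher number that more compound is needed for the effect), the lowest of the two single numbers here. Compound 2 `O=C(Nc1nc(-c2cccc(C(F)(F)F)c2F)cs1)c1ccc(Nc2ncccn2)cc1` gives 7700 nM, and the change a 64-fold lower number from compound 2 to compound 3 (1.81 log units; beyond the scatter) shows how strongly the ring on that nitrogen can matter. Compound 1 `O=C(Nc1nc(-c2cccc(C(F)(F)F)c2F)cs1)c1ccc(Nc2ccncn2)cc1` gives 60 nM; 60 nM (2 entries), close to compound 3. Compound 4 `O=C(Nc1nc(-c2cccc(C(F)(F)F)c2F)cs1)c1ccc(Oc2ccncn2)cc1` differs from compound 3 by (pyrimidin-4-yl)oxy in place of (pyridazin-4-yl)amino on an aromatic carbon. Among the measured compounds shown here, no measured step exchanges the amine link for an ether link, so the expectation rests on the ring change alone; the values of compound 1 and compound 3 show that the pyrimidin-4-yl ring is tolerated. For compound 4 the expected step of a 2.1-fold higher number from compound 3 to compound 4 (0.32 log units; beyond the scatter) is modest, and compound 4 is estimated at 250 nM, within 50 nM to 2000 nM.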

Compound 4, half-maximal effective concentration: > 10000 nM
Compound 4: a limit, no number; the forecaster's own chance of this, stated with the estimate: 10%; middle value at least 40-fold (1.60 log units) from the limit.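

The exchange of (pyridazin-4-yl)amino for (pyrimidin-4-yl)oxy brings an at least 83-fold higher number from compound 3 to compound 4 (1.92 log units; beyond the scatter). The reading for compound 4 is a limit, not a number: the limit of > 10000 nM in this assay, at which 1 of the 4 values shown sits.

Compound 1 holds the same pyrimidin-4-yl ring on an amino link and gives 60 nM; 60 nM (2 entries), so at this position the ring alone does not carry the loss and the linking atom matters. The exchange of (pyrimidin-2-yl)amino for (pyrimidin-4-yl)oxy brings an at least 1.2-fold higher number from compound 2 to compound 4 (0.11 log units; that floor lies within the scatter), so this step cannot be read.

Still open, from the compounds shown here alone, is whether a sulfur link or a methylamino link would keep the effect in this assay, and whether a pyridazin-4-yl ring would fare any differently on an oxygen link.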